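Removing one fluorine from the difluorophenyl end

The compounds below may be only part of what the source reports. "The series", "measured", "known", "first", "only" and "open" are said of these compounds alone.

Measured so far:
Compound 1 `CN(C(=O)NC(=O)c1ccc(F)c(F)c1)c1nc(C(F)(F)F)c(C(=O)N/N=C/c2ccc(C(F)(F)F)cc2)s1`: 5.1 ug/mL
Compound 2 `CN(C(=O)NC(=O)c1ccc(C(F)(F)F)cc1)c1nc(C(F)(F)F)c(C(=O)N/N=C/c2ccc(C(F)(F)F)cc2)s1`: limit > 100 ug/mL
Compound 3 `CN(C(=O)NC(=O)c1c(F)cccc1F)c1nc(C(F)(F)F)c(C(=O)N/N=C/c2ccc(C(F)(F)F)cc2)s1`: 30.6 ug/mL

In a functional assay on HeLa cells (Homo sapiens) for inhibition, read by MTT assay, with a stated time of 72 h (on this read-out lower numbers stand for stronger inhibition and higher numbers for weaker inhibition), compound 1 gives 5.1 ug/mL. Compound 2 reaches only the assay limit > 100 ug/mL, a bound rather than a number (the limit of > 100 ug/mL in this assay, at which 1 of the 3 values shown sits). Compound 3 gives 30.6 ug/mL, the highest of the two numbers, with a 6.0-fold higher number from compound 1 to compound 3 (0.78 log units; beyond the scatter) and an at least 3.2-fold lower number from compound 2 to compound 3 (0.51 log units; beyond the scatter). Compound 4 `CN(C(=O)NC(=O)c1ccccc1F)c1nc(C(F)(F)F)c(C(=O)N/N=C/c2ccc(C(F)(F)F)cc2)s1` differs from compound 3 only by hydrogen in place of fluoro on an aromatic carbon. The measured steps all swap the whole aryl ring and so bear on this change only loosely, though they show that this ring matters. A moderate shift in either direction is expected for compound 4, estimated at 20 ug/mL (range 5 ug/mL to 80 ug/mL), meaning an expected step of a 1.5-fold lower number from compound 3 to compound 4 (0.18 log units; within the scatter).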

Compound 4, half-maximal inhibitory concentration: 3.97 ug/mL
Compound 4: middle estimate off by 5.0-fold (0.70 log units), on the high side, and the stated range ends above it.
By their numbers in this assay, from the lowest: compounds 4 and 1 (each within the scatter of the next); then compound 3. At a limit, above all of these: compound 2.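

Hydrogen in place of fluoro on this aromatic carbon, ortho to a large group, gives a 7.7-fold lower number from compound 3 to compound 4 (0.89 log units; beyond the scatter) in this assay, so a single atom at this place can shift the result beyond the scatter. The 2-fluorophenyl and 3,4-difluorophenyl groups cannot be told apart here, with a 1.3-fold lower number from compound 1 to compound 4 (0.11 log units; within the scatter). The remaining step, an at least 25-fold lower number from compound 2 to compound 4 (1.40 log units; beyond the scatter), starts from a limit and not a number: the limit of > 100 ug/mL in this assay, at which 1 of the 4 values shown sits.

Still open, going by these compounds, is how a plain phenyl group would read, with hydrogen in place of the remaining fluoro. Also open, on these data alone, is whether chloro or methoxy in place of that fluoro would behave like fluoro or like hydrogen.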